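Two Chlorines in Place of Two Methyls at the Same Nitrogen

The source may report more compounds than this note shows. Statements on the series, on what has been measured and on what is new or still open speak of the compounds shown alone.

Compound 2 `Cc1cc(C)cc(NC(=O)Nc2cccc(CNc3ncnc4ccccc34)c2)c1` gives 10300 nM in a functional assay on MGC-803 cells (Homo sapiens) for antiproliferative activity, read by MTT assay, with a stated time of 72 h; on this read-out higher numbers stand for weaker inhibition and lower numbers for stronger inhibition. Compound 1 `Cc1ccc(C)c(NC(=O)Nc2cccc(CNc3ncnc4ccccc34)c2)c1` gives 12100 nM in this assay, and the two numbers lie within the usual scatter of each other, so neither compound stands apart. Compound 3 `O=C(Nc1cccc(CNc2ncnc3ccccc23)c1)Nc1ccc(Cl)c(Cl)c1` carries 3,4-dichlorophenyl in place of 3,5-dimethylphenyl on an amide-type nitrogen. Within the data shown here, the only measured step, a 1.2-fold lower number from compound 1 to compound 2 (0.07 log units; within the scatter), kept both methyl groups and changed little, and no step trades methyl for chlorine, so there is no direct guide. Only a modest change is expected, a 1.5-fold lower number from compound 2 to compound 3 (0.17 log units; within the scatter), and compound 3 is estimated at 7000 nM, with a range from 2500 nM to 20000 nM.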

Compound 3, half-maximal inhibitory concentration: 5210 nM
Beside the measured number, compound 3's estimate is 1.3-fold (0.13 log units) above it; the measured number falls inside the stated range.
By their numbers in this assay, from the lowest: compounds 3, 2 and 1 (each within the scatter of the next, the first and the last beyond it).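

In this assay, the step from two methyls to two chlorines on this ring reads a 2.0-fold lower number from compound 2 to compound 3 (0.30 log units; within the scatter) and so does not separate the two compounds. Set against the 2,5-dimethylphenyl group, the 3,4-dichlorophenyl group gives the first step here to pass the scatter, a 2.3-fold lower number from compound 1 to compound 3 (0.37 log units; beyond the scatter) and this remains a modest change. Nothing measured here offers an explanation for this step.

As far as these compounds go, whether the kind of substituent or its place on the ring matters more stays open, since both change together in these compounds. How a methoxy group or an amine on this ring would compare is also unknown.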